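The source may hold more compounds than are shown below. What is called first, only, known or untested is meant among the compounds shown, and "the series" means these compounds.

In an ADME assay on NIH3T3 cells (Mus musculus) for cytotoxicity, read by MTT assay, with a stated time of 24 h (a higher number here means a weaker inhibitor, a lower number a stronger inhibitor), compound 1 (`N#Cc1ccc(-c2cs/c(=N/NC(=O)CSc3ncccn3)n2-c2ccccc2)cc1`) gives < 3.9 ug/mL, which is a limit of the assay and not a number. Compound 2 (`Cn1cnnc1SCC(=O)N/N=c1/scc(-c2ccc([N+](=O)[O-])cc2)n1-c1ccccc1`) gives 133 ug/mL, and compound 3 (`Cc1ccc(-c2cs/c(=N/NC(=O)CSc3nncn3C)n2-c2ccccc2)cc1`) gives 130 ug/mL. Compound 4 (`O=C(CSc1ncccn1)N/N=c1/scc(-c2ccc(Br)cc2)n1-c1ccccc1`) keeps the core of compound 1 and differs from it by bromo in place of cyano on an aromatic carbon. Among the compounds with values here, the one measured step that bears on this change, with methyl in place of nitro on an aromatic carbon, is a 1.0-fold lower number from compound 2 to compound 3 (0.01 log units; within the scatter). No step beyond the scatter is therefore expected in this assay. The expected step is a step that the limit leaves unreadable from compound 1 to compound 4. For compound 4 the estimate is 3.5 ug/mL, with an expected range of 1 ug/mL to 20 ug/mL.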

Compound 4, half-maximal inhibitory concentration: 273 ug/mL
Compound 4: middle estimate off by 78-fold (1.89 log units), on the low side; measured number above the stated range.
By their numbers in this assay, from the lowest: compounds 3 and 2 (each within the scatter of the next); then compound 4. At a limit, below all of these: compound 1.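

In this assay there is an at least 70-fold higher number from compound 1 to compound 4 (1.84 log units; beyond the scatter) with bromo in place of cyano on an aromatic carbon, so the number at this place can move well beyond the scatter, whereas a 1.0-fold lower number from compound 2 to compound 3 (0.01 log units; within the scatter) came with methyl in place of nitro. The value of compound 1 is a limit of the assay and not a number, so the size of its step is only a bound: the limit of < 3.9 ug/mL in this assay, at which 1 of the 4 values shown sits.

The compounds shown leave open how far compound 1 truly lies from compound 4. They also leave open whether an amine or a carboxylic acid in this place on the core of compound 1 would give a number nearer compound 1 or compound 4.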